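From 3-fluorophenyl to 4-nitrophenyl: an expected step

This account rests on a few compounds, and the source may have more. Where it says the series, first, only, none or still open, it means among the compounds named here.

Of the compounds shown here, three from one series have been tested in a functional assay on MDA-MB-231 cells (Homo sapiens) for cytotoxicity, read by MTT assay, with a stated time of 72 h; on this read-out lower numbers stand for stronger inhibition and higher numbers for weaker inhibition. Compound 1 `COc1cc2c(Oc3ccc(NC(=O)c4nn(-c5ccc([N+](=O)[O-])cc5)c(=O)c5ccccc45)cc3F)ccnc2cc1OCCCN1CCCC1` gives 2980 nM, and compound 2 `COc1cc2c(Oc3ccc(NC(=O)c4nn(-c5ccc([N+](=O)[O-])cc5)c(=O)c5ccccc45)cc3F)ccnc2cc1OCCCN1CCN(C)CC1` gives 3490 nM. Between them a 1.2-fold higher number from compound 1 to compound 2 (0.07 log units; within the scatter), so the change of amine at the end of the chain makes no difference that can be trusted. Compound 3 `COc1cc2c(Oc3ccc(NC(=O)c4nn(-c5cccc(F)c5)c(=O)c5ccccc45)cc3F)ccnc2cc1OCCCN1CCC(C)CC1` gives 860 nM, the lowest of the three numbers, and its gaps to compound 1 and to compound 2 are both beyond the scatter.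

Compound 4 `COc1cc2c(Oc3ccc(NC(=O)c4nn(-c5ccc([N+](=O)[O-])cc5)c(=O)c5ccccc45)cc3F)ccnc2cc1OCCCN1CCC(C)CC1` has not yet been measured. It differs from compound 3 in one place: 4-nitrophenyl in place of 3-fluorophenyl on an aromatic nitrogen. Among the compounds with values here, no measured step involves this change directly. Within the data shown here, compounds 1 and 2 already carry the 4-nitrophenyl group and differ from compound 4 only in the amine, and the one measured step shows that the amine matters little. On that basis compound 4 is expected to move toward the numbers of compound 1 and compound 2, with an estimated step of a 2.9-fold higher number from compound 3 to compound 4 (0.46 log units; beyond the scatter) in this assay. The expected value for compound 4 is 2500 nM, in an estimated range from 1000 nM to 6000 nM.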

Compound 4, half-maximal inhibitory concentration: 4010 nM
For compound 4 the middle estimate is 1.6-fold (0.21 log units) below the measured one; low and high end bracket the measured number.
By their numbers in this assay, from the lowest: compound 3; then compounds 1, 2 and 4 (each within the scatter of the next).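

In this assay, the group on the aromatic nitrogen now has a direct measured step: with the 4-methylpiperidin-1-yl end of the chain held fixed, 4-nitrophenyl in place of 3-fluorophenyl gives a 4.7-fold higher number from compound 3 to compound 4 (0.67 log units; beyond the scatter), so a change at this position can shift the number by more than the scatter. With 4-nitrophenyl in place, the amine at the chain end makes no difference that can be trusted across all three amines, with a 1.1-fold higher number from compound 2 to compound 4 (0.06 log units; within the scatter) and a 1.3-fold higher number from compound 1 to compound 4 (0.13 log units; within the scatter). Nothing measured here bears on the reason for the step at the aromatic nitrogen.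

This swap changes both the group on the ring and where it sits, so 3-nitrophenyl or 4-fluorophenyl on the same nitrogen would be needed to separate the two. From the compounds shown here alone, it also remains open whether the amine matters as little alongside 3-fluorophenyl, which a pyrrolidin-1-yl or 4-methylpiperazin-1-yl chain end paired with that group could show.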